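Hydrazone aryl variation at the imine carbon

A few compounds are considered here, and "the series" means these few. Any claim that something is new, unique, unknown or untested is made for them only; others in the source may bear on it.

Measured compounds:
compound 1 `CCCCC/C=C/C=C/C=N/Nc1nc(N)c2ncn([C@@H]3O[C@H](CO)[C@@H](O)[C@H]3O)c2n1` 2 nM
compound 2 `Nc1nc(N/N=C/c2cncs2)nc2c1ncn2[C@@H]1O[C@H](CO)[C@@H](O)[C@H]1O` 22 nM
compound 3 `Nc1nc(N/N=C/c2ccc3ncccc3c2)nc2c1ncn2[C@@H]1O[C@H](CO)[C@@H](O)[C@H]1O` 9.8 nM

In an assay on CHO-K1 cells for displacement of a labelled ligand from adenosine receptor A1 (Homo sapiens), read by scintillation counting, with a stated time of 60 min (on this read-out lower numbers stand for stronger inhibition and higher numbers for weaker inhibition), compound 3 sits second highest of the three numbers: compound 1 gives 2 nM, and the step of a 4.9-fold higher number from compound 1 to compound 3 (0.69 log units; beyond the scatter) is modest. Compound 2 gives 22 nM; the step of a 2.2-fold lower number from compound 2 to compound 3 (0.35 log units; beyond the scatter) is also modest, while an 11-fold higher number from compound 1 to compound 2 (1.04 log units; beyond the scatter) is the largest step in the set.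

Compound 4 `CCOc1cc(/C=N/Nc2nc(N)c3ncn([C@@H]4O[C@H](CO)[C@@H](O)[C@H]4O)c3n2)ccc1O` carries the change (3-ethoxy-4-hydroxyphenyl in place of quinolin-6-yl on a carbon with a double bond to nitrogen). Among the measured compounds shown here, no measured step exchanges one aromatic group for another of the same ring count; the nearest comparison is the step from compound 2 to compound 3, where swapping one aromatic group for another moved this assay only modestly. Both aromatic replacements of the chain of compound 1 gave higher numbers, so aromatic groups at this position have so far clustered within a narrow band.

For compound 4 a step of roughly a 1.5-fold higher number from compound 3 to compound 4 (0.18 log units; within the scatter) is therefore expected, a slightly higher number than compound 3, at the edge of the scatter. The expected value for compound 4 in this assay is 15 nM, with a range of 5 nM to 50 nM.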

Compound 4, inhibition constant: 6940 nM
The estimate for compound 4 lay 460-fold (2.67 log units) below the measured number; measured number above the stated range.
By their numbers in this assay, from the lowest: compound 1; then compound 3; then compound 2; then compound 4.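

Aromatic groups on the carbon with a double bond to nitrogen do not all fall in one narrow band in this assay: the series shows a 710-fold higher number from compound 3 to compound 4 (2.85 log units; beyond the scatter), together with a 320-fold higher number from compound 2 to compound 4 (2.50 log units; beyond the scatter), and the overall span now reaches a 3500-fold higher number from compound 1 to compound 4 (3.54 log units; beyond the scatter). Neither the heavy-atom count nor the number of rings tracks this loss on its own, since 3-ethoxy-4-hydroxyphenyl has the same count of 10 heavy atoms as quinolin-6-yl, while 1,3-thiazol-5-yl goes against a ring-count reading by carrying a single aromatic ring, as 3-ethoxy-4-hydroxyphenyl does, yet staying far closer to compound 3. No measurement on hand accounts for the size of this step.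

The compounds shown leave open whether the ethoxy group, the hydroxy group or only the two together carry the loss, a question that 3-ethoxyphenyl, 4-hydroxyphenyl and unsubstituted phenyl at the same carbon would separate. Also open, from the compounds shown here alone, is whether a methoxy group or a longer alkoxy chain in place of the ethoxy group would give a number nearer to that of compound 3 or further from it.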